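A few compounds are considered here, and "the series" means these few. Any claim that something is new, unique, unknown or untested is made for them only; others in the source may bear on it.

Working notes on the series.

Three compounds have numbers in a functional assay on PC-9 cells (Homo sapiens) for inhibition, read by MTT assay, with a stated time of 48 h, tested at 10 uM; a higher number here means more inhibition at the concentration tested (going by the name of the read-out), a lower number less inhibition. Compound 1, `COc1ccc(OC)c(Nc2cc(NC(=O)Nc3c(Cl)cccc3Cl)ncn2)c1`, gives 95% in this assay. Compound 2, `Cc1ccc(Nc2cc(NC(=O)Nc3c(Cl)cccc3Cl)ncn2)cc1F`, gives 92%. Compound 3, `COc1cc(NC(=O)Nc2cc(Nc3cc(C)cc(F)c3)ncn2)cc(OC)c1`, gives 64.5% and so stands lowest of the three; its nearest neighbour in the numbers is compound 2, a gap beyond the scatter, and the gap to compound 1 is wider still. No two of these three differ in only one place, so no single change can be tied to any of those gaps; compound 1 and compound 2 share one pattern of substitution on the shared core, compound 3 carries it the other way round, and that is all the numbers show.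

The next compound, compound 4, `COc1cc(NC(=O)Nc2cc(Nc3ccc(C(C)(C)C)cc3)ncn2)cc(OC)c1`, follows from compound 3 by one change: 4-(tert-butyl)phenyl in place of 3-fluoro-5-methylphenyl on a nitrogen on an aromatic ring. Going by the values given here, no measured pair isolates a change of this kind, so there is nothing to lean on beyond the value of compound 3 itself. The expected step from compound 3 to compound 4 in this assay is a number 4.5 percentage points lower from compound 3 to compound 4 (within the scatter), which is taken to lie within the scatter, with no clear direction. Compound 4 is therefore estimated at 60%, with a range from 30% to 85%.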

Compound 4, a percentage reported as inhibition, at one concentration (the size of the read-out at that concentration, not a potency): 74.1%
The estimate for compound 4 lay 14.1 percentage points below the measured number; measured number inside the range.
By their numbers in this assay, from the lowest: compounds 3 and 4 (each within the scatter of the next); then compounds 2 and 1 (each within the scatter of the next).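

In this assay, going by these compounds alone, the exchange of 3-fluoro-5-methylphenyl (8 heavy atoms, one of them fluorine) for 4-(tert-butyl)phenyl (10 heavy atoms, all carbon) on a nitrogen on an aromatic ring gives a number 9.6 percentage points higher from compound 3 to compound 4 (within the scatter), the first step that isolates a single place. With the rest of compound 3 held constant, a different substitution pattern and a larger, all-carbon group at this place therefore bring no change in the read-out beyond the scatter, so neither group can be ranked over the other here. Nothing measured alongside these numbers accounts for the step.

This single pair leaves open what number other groups at this place would give in this assay, for instance an unsubstituted phenyl or a phenyl carrying a morpholine or a carboxylic acid in place of the tert-butyl group. It also leaves open whether the same exchange would give a comparable step on the dichlorophenyl urea of compound 2, where the surrounding structure differs from that of compound 3.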